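Methyl on the chain carbon of compound 1

A few compounds are considered here, and "the series" means these few. Any claim that something is new, unique, unknown or untested is made for them only; others in the source may bear on it.

Compound 1 `Cn1c([N+](=O)[O-])cnc1C(=O)NCc1ccc(F)cc1`: > 100000 nM
Compound 2 `COc1ccc(CNC(=O)c2ncc([N+](=O)[O-])n2C)cc1`: > 100000 nM

In a toxicity assay on HEK293 cells (Homo sapiens) for inhibition, read by resazurin assay, with a stated time of 24 h (a lower number here means that less compound is tolerated, a higher number that more compound is tolerated), compound 1 gives > 100000 nM, which is a limit and not a number. Compound 2 gives > 100000 nM, also a limit. The whole measured picture is therefore (the limit of > 100000 nM in this assay, at which 2 of the 2 values shown sit).

Compound 3 `CC(NC(=O)c1ncc([N+](=O)[O-])n1C)c1ccc(F)cc1` differs from compound 1 by methyl in place of hydrogen on a saturated chain carbon bound to an amide-type nitrogen and an aromatic carbon. Among the measured compounds shown here, the only measured step is a step that the two limits leave unreadable from compound 1 to compound 2. It involves an aromatic carbon rather than the chain carbon changed here, so it bears only indirectly and gives no size to carry over. With no readable step in this assay, no direction is expected, and the estimated step of a number no higher from compound 1 to compound 3 (the limit leaves the size open) is expected to stay within the scatter. The expected value for compound 3 is 100000 nM, with an estimated range from 50000 nM to 200000 nM.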

Compound 3, half-maximal cytotoxic concentration: > 100000 nM
Compound 3: no number, only a limit; the forecaster's own chance of this, stated with the estimate: 85%; the middle value sits exactly at the limit.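

The step between compound 1 and compound 3 cannot be read because the values of both are limits: the limit of > 100000 nM in this assay, at which 3 of the 3 values shown sit.

The compounds shown leave open at what concentration any of them stops being tolerated in this assay, and whether methyl in place of hydrogen or methoxy in place of fluoro changes that concentration.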